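A few compounds are considered here, and "the series" means these few. Any claim that something is new, unique, unknown or untested is made for them only; others in the source may bear on it.

Measured so far in an assay on cells for displacement of a labelled ligand from prostaglandin E2 receptor EP4 subtype (Homo sapiens), read by scintillation counting; a higher number here means a weaker inhibitor, a lower number a stronger inhibitor:
Compound 1 `CC(=O)c1ccc(-c2ccc(OCc3cc(C(=O)O)oc3C)cc2)cc1` gives 150 nM.
Compound 2 `Cc1oc(C(=O)O)cc1COc1ccc(-c2ccc(CO)cc2)cc1` gives 3000 nM.
Compound 3 `Cc1oc(C(=O)O)cc1COc1ccc(-c2ccoc2)cc1` gives only a limit of the assay, > 10000 nM.

Compound 2 stands at the highest of the two plain numbers. Its nearest neighbour is compound 1, and the step between the two is a 20-fold higher number from compound 1 to compound 2 (1.30 log units; beyond the scatter), with hydroxymethyl in place of acetyl on an aromatic carbon. The third value is a limit, (the limit of > 10000 nM in this assay, at which 1 of the 3 values shown sits), and so cannot be placed in order with the other two.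

Compound 4 `Cc1oc(C(=O)O)cc1COc1ccc(-c2ccc(OC(F)(F)F)cc2)cc1` is the next compound. It differs from compound 2 in one place: trifluoromethoxy in place of hydroxymethyl on an aromatic carbon. The group that leaves carries a hydrogen-bond donor; the group that enters carries none, as acetyl in compound 1 carries none.

For the measured compounds named here, two measured steps bear on this change. The step of a 20-fold higher number from compound 1 to compound 2 (1.30 log units; beyond the scatter) shows how much the number rose when acetyl gave way to hydroxymethyl, and the step of an at least 3.3-fold higher number from compound 2 to compound 3 (0.52 log units; beyond the scatter) shows a further rise when the whole outer ring was replaced by furan-3-yl. Taken together, they suggest that a group without a donor on that ring position tends to give a lower number than hydroxymethyl, though only compound 1 shows this directly. The expected step is therefore downward, a 3.8-fold lower number from compound 2 to compound 4 (0.57 log units; beyond the scatter), smaller than the step to compound 1. The estimate for compound 4 in this assay is 800 nM, expected to lie between 200 nM and 4000 nM.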

Compound 4, inhibition constant: 2400 nM
Estimate against measurement, compound 4: 3.0-fold (0.48 log units) below; low and high end bracket the measured number.
By their numbers in this assay, from the lowest: compound 1; then compounds 4 and 2 (each within the scatter of the next). At a limit, above all of these: compound 3.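

In this assay, taking away the hydrogen-bond donor of hydroxymethyl is not enough on its own to shift the number, since trifluoromethoxy, which carries no donor, gives a 1.3-fold lower number from compound 2 to compound 4 (0.10 log units; within the scatter) and so cannot be told apart from hydroxymethyl here. Acetyl, which also carries no donor, stands apart from trifluoromethoxy at this same place on the ring, with a 16-fold higher number from compound 1 to compound 4 (1.20 log units; beyond the scatter) as the step, so among the compounds shown, compound 4 goes against the idea that any group without a donor matches compound 1. Nothing measured here accounts for why acetyl differs from the other two groups.

Still open, going by these compounds, is whether the carbonyl of acetyl is what sets compound 1 apart, a question that a primary amide, a methyl ester or a propanoyl group at the same place could test. It is also unclear how a nitrile or an amine there would compare with acetyl and trifluoromethoxy on the shared core.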